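The source may report more compounds than this note shows. Statements on the series, on what has been measured and on what is new or still open speak of the compounds shown alone.

Measured compounds:
- compound 1 `O=C(Nc1ccc(Cl)cc1)NS(=O)(=O)c1cc2ccccc2o1`, giving 84% in a functional assay on the whole organism (Mus musculus) for inhibition, at a dose of 150 mg/kg by the oral route; a higher number here means more inhibition at the dose given (going by the name of the read-out), a lower number less inhibition
- compound 2 `COc1ccc2oc(S(=O)(=O)NC(=O)Nc3ccc(Cl)cc3)cc2c1`, giving 25%
- compound 3 `O=C(Nc1ccc(Cl)cc1)NS(=O)(=O)c1cc2cc(Cl)ccc2o1`, giving 40%

Compound 1 stands highest of the three; the nearest is compound 3, with a number 44 percentage points lower from compound 1 to compound 3 (beyond the scatter), and the furthest is compound 2, with a number 59 percentage points lower from compound 1 to compound 2 (beyond the scatter). Both of those steps change the shared core, not the other ring. Compound 4 `O=C(Nc1ccc(Cl)c(Cl)c1)NS(=O)(=O)c1cc2ccccc2o1` differs from compound 1 by chloro in place of hydrogen on an aromatic carbon. For the measured compounds named here, no measured step touches that ring, so the two large drops seen so far do not transfer directly; they only show that small additions can cost a great deal here. A modest loss is therefore expected, with wide uncertainty: compound 4 is estimated at 55%, between 15% and 90%, meaning an expected step of a number 29 percentage points lower from compound 1 to compound 4 (beyond the scatter).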

Compound 4, a percentage reported as inhibition, in the whole organism at one dose (the size of the read-out at that dose, not a potency): 28%
Estimate against measurement, compound 4: 27 percentage points above, and the stated range covers the measured number.
By their numbers in this assay, from the lowest: compounds 2 and 4 (each within the scatter of the next); then compound 3; then compound 1.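

The 4-chlorophenyl to 3,4-dichlorophenyl change gives, in this assay, a number 56 percentage points lower from compound 1 to compound 4 (beyond the scatter). The shared core is therefore not the only sensitive part: a single added chloro on the other ring, at a carbon ortho to the existing chloro group, also brings a large loss. No measurement available here accounts for this loss. Going by these compounds, whether a fluoro or a methyl group in this place would cost as much stays open. So does the outcome with an amine or a carboxylic acid there.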